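The compounds below may be only part of what the source reports. "The series", "measured", "known", "first", "only" and "open" are said of these compounds alone.

Measured compounds in a functional assay on MKN-45 cells (Homo sapiens) for cytotoxicity, read by MTT assay, with a stated time of 72 h; a lower number here means a stronger inhibitor, a higher number a weaker inhibitor:
compound 1 `CCN(CC)CCCNc1nc(-c2ccc(NC(=O)Nc3ccccc3Cl)cc2)nc2c(Cl)c(Cl)sc12`, with 1450 nM;
compound 2 `CCN(CC)CCCNc1nc(-c2ccc(NC(=O)Nc3ccc(Cl)cc3Cl)cc2)nc2c(Cl)c(Cl)sc12`, with 5720 nM;
compound 3 `CCN(CC)CCCNc1nc(-c2ccc(NC(=O)Nc3ccc(C)cc3)cc2)nc2c(Cl)c(Cl)sc12`, with 3320 nM.

Compound 2 gives the highest of the three numbers, although its step to compound 3 a 1.7-fold lower number from compound 2 to compound 3 (0.24 log units; within the scatter) lies within the scatter, while compound 1 lies further off a 3.9-fold higher number from compound 1 to compound 2 (0.60 log units; beyond the scatter). Compound 4 `CCN(CC)CCNc1nc(-c2ccc(NC(=O)Nc3ccc(Cl)cc3Cl)cc2)nc2c(Cl)c(Cl)sc12` differs from compound 2 by diethylamino in place of (diethylamino)methyl on a saturated chain carbon, two bonds along the chain from a nitrogen on an aromatic ring. Neither of the steps seen so far touches this chain: a 3.9-fold higher number from compound 1 to compound 2 (0.60 log units; beyond the scatter) and a 2.3-fold higher number from compound 1 to compound 3 (0.36 log units; beyond the scatter) both alter the aryl on the urea nitrogen, leaving the chain untouched. With nothing to anchor the change, no step beyond the scatter is expected in this assay in either direction. Compound 4 is therefore estimated at 5700 nM, between 2000 nM and 16000 nM, a step of a 1.0-fold lower number from compound 2 to compound 4 (0.00 log units; within the scatter).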

Compound 4, half-maximal inhibitory concentration: 1770 nM
Beside the measured number, compound 4's estimate is 3.2-fold (0.51 log units) above it; measured number below the stated range.
By their numbers in this assay, from the lowest: compounds 1, 4, 3 and 2 (each within the scatter of the next, the first and the last beyond it).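

With the 2,4-dichlorophenyl on the urea held fixed, going from 3-(diethylamino)propyl to 2-(diethylamino)ethyl gives in this assay a 3.2-fold lower number from compound 2 to compound 4 (0.51 log units; beyond the scatter). Among these compounds, this shows that the chain, which none of the earlier steps touched, can by itself move the number beyond the scatter, so the position is not silent. Nothing at hand accounts for this step.

As far as these compounds go, whether the same shortening holds with the 2-chlorophenyl of compound 1 or the 4-methylphenyl of compound 3 stays open. So does the effect of a longer chain, or of a morpholine or pyrrolidine in place of the diethylamino.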